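The source may hold more compounds than are shown below. What is called first, only, known or untested is meant among the compounds shown, and "the series" means these compounds.

Measured so far:
- Compound 1, `COc1ccc(CNc2cc(OC)c(OC)c(OC)c2)cc1[N+](=O)[O-]`: in a functional assay on HCT-116 cells (Homo sapiens) for inhibition, read by MTT assay, with a stated time of 48 h (a higher number here means a weaker inhibitor, a lower number a stronger inhibitor), compound 1 gives 18200 nM
- Compound 2, `COc1ccc(CN(C(C)=O)c2cc(OC)c(OC)c(OC)c2)cc1O`: in this assay compound 2 gives 270 nM
- Compound 3, `C/C=C/C(=O)N(Cc1cc(OC)c(OC)c(OC)c1)c1ccc(OC)c(O)c1`: in this assay compound 3 gives 8450 nM

Of the three measured compounds, compound 2 holds the lowest number, and both gaps to it lie beyond the scatter. The nearest value is that of compound 3, whose number stands well above that of compound 2, while compound 1 stands furthest away with a much higher number still. Compound 2 is therefore the strongest inhibitor of the three in this assay.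

The step under study leads from compound 2 to the unmeasured compound 4, `COc1ccc(CN(C(=O)CBr)c2cc(OC)c(OC)c(OC)c2)cc1O`. The two structures differ in one place: bromo in place of hydrogen on a saturated chain carbon bound to a carbonyl carbon. Among the compounds with values here, no step between measured compounds is available to calibrate a change of this kind, so the expectation rests on the standing of compound 2 alone.

The account expects the step from compound 2 to compound 4 in this assay to be a modest move toward a lower number, estimated as a 2.3-fold lower number from compound 2 to compound 4 (0.35 log units; beyond the scatter), though a result within the scatter would not surprise. Compound 4 is accordingly estimated at 120 nM, with a range from 25 nM to 600 nM.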

Compound 4, half-maximal inhibitory concentration: 68 nM
Estimate against measurement, compound 4: 1.8-fold (0.25 log units) above; measured number inside the range.
By their numbers in this assay, from the lowest: compound 4; then compound 2; then compound 3; then compound 1.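

Putting bromo in place of hydrogen on a saturated chain carbon bound to a carbonyl carbon, the change from acetyl to (bromomethyl)carbonyl, gives in this assay a 4.0-fold lower number from compound 2 to compound 4 (0.60 log units; beyond the scatter), a modest but real step. Within the data shown here, this is the first comparison between compounds that differ in one place, so it is the first direct reading of this position: the methyl of the acetyl group can take a bromo, one added heavy atom, and inhibition is not lost but improves. What lies behind the fall in the number remains unexplained, as no measurement shown here speaks to its cause.

The compounds shown leave open whether this gain belongs to bromo itself or would also come with chloro, a hydroxyl or an amine on the same carbon. They also leave open whether the bromo would keep the lower number on a longer chain, such as bromopropanoyl, in place of the (bromomethyl)carbonyl group.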